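A few compounds are considered here, and "the series" means these few. Any claim that something is new, unique, unknown or untested is made for them only; others in the source may bear on it.

- compound 1 `CCOc1nc(C)c(Nc2nc(Cl)cn([C@H](C)C3CC3)c2=O)cc1C` 93%
- compound 2 `Cc1cc(OC(F)F)nc(C)c1Nc1nc(Cl)cn([C@H](C)C2CC2)c1=O` 89%

In an ADME assay on microsomes from liver (Rattus norvegicus) for metabolic stability, with a stated time of 10 min (on this read-out lower numbers stand for a less stable compound and higher numbers for a more stable compound), compound 1 gives 93% and stands within the scatter of compound 2 at 89% on this read-out. Compound 3 `Cc1cc(Nc2nc(Cl)cn([C@H](C)C3CC3)c2=O)c(C)nc1OC(F)F` has not yet been measured. Going by the values given here, it differs from compound 1 by difluoromethyl in place of ethyl on an oxygen on an aromatic ring and no measured pair shows this change alone. Compound 2 also carries difluoromethoxy and gives 89% here, so a number 5 percentage points lower from compound 1 to compound 3 (within the scatter) is expected to be small and not beyond the scatter. For compound 3 the estimate is 88% with 74% to 98% as the expected range.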

Compound 3, percent of the compound remaining: 100%
Estimate against measurement, compound 3: 12 percentage points below, and the stated range ends below it.
By their numbers in this assay, from the lowest: compounds 2, 1 and 3 (each within the scatter of the next, the first and the last beyond it).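

In this assay, the change from ethoxy to difluoromethoxy gives a number 7 percentage points higher from compound 1 to compound 3 (within the scatter). Going by these compounds alone, this is the first direct reading of the change on its own, and it shows that this oxygen on an aromatic ring can carry either group with no difference that stands out from the scatter on this read-out. Nothing available explains this result.

On these data alone, what a longer chain such as butyl, or an amine in place of the oxygen-linked group, would do here remains open. So does whether the swap would behave the same way on a different core.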